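The source may hold more compounds than are shown below. What is called first, only, known or untested is meant among the compounds shown, and "the series" means these compounds.

Measured compounds in an ADME assay on Vero cells (Chlorocebus sabaeus) for cytotoxicity, read by MTT assay, with a stated time of 72 h; on this read-out lower numbers stand for higher toxicity in this test and higher numbers for lower toxicity in this test:
- compound 1 `O=c1nc(N2CCN(NCc3ccc(F)cc3)CC2)sc2c([N+](=O)[O-])cc(C(F)(F)F)cc12`: a limit of the assay, > 64 ug/mL
- compound 2 `Cc1ccc(CNN2CCN(c3nc(=O)c4cc(C(F)(F)F)cc([N+](=O)[O-])c4s3)CC2)cc1`: a limit of the assay, > 64 ug/mL

Compound 2 stands at a limit in this assay, not at a number. The same holds for compound 1, so both values shown sit at the limit of > 64 ug/mL in this assay, at which 2 of the 2 values shown sit. Among the measured compounds shown here, the one step between measured compounds, a step that the two limits leave unreadable from compound 1 to compound 2, is therefore not readable in size or direction.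

Compound 3 `COc1ccc(CNN2CCN(c3nc(=O)c4cc(C(F)(F)F)cc([N+](=O)[O-])c4s3)CC2)cc1` differs from compound 2 by methoxy in place of methyl on an aromatic carbon. For the measured compounds named here, the only measured step that bears on this change is the one from compound 1 to compound 2, and it gives no readable size. Going by the values given here, nothing among the measured compounds points to a shift beyond the usual scatter, and nothing rules one out. The working expectation is that compound 3 also lands at or beyond the limit of this assay.

On that basis compound 3 is estimated at 100 ug/mL in this assay, with a range of 50 ug/mL to 200 ug/mL. The expected step is a step that the limit leaves unreadable from compound 2 to compound 3, within the scatter.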

Compound 3, half-maximal cytotoxic concentration: > 64 ug/mL
Compound 3 ended at the assay's limit; the forecaster's own chance of this, stated with the estimate: 80%; the middle value does not contradict the limit.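

No step in size or direction can be read among compound 1, compound 2 and compound 3 in this assay, as each value is a limit and not a number: the limit of > 64 ug/mL in this assay, at which 3 of the 3 values shown sit.

The compounds shown leave open how far each true value lies past this limit, and whether fluoro, methyl or methoxy on the aromatic carbon changes the read-out of this assay at all.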